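The compounds below may be only part of what the source reports. "The series", "measured", "known", "first", "only" and "open" are said of these compounds alone.

Compound 1 `CNc1nncc2cncn12` gives > 48000 nM in a functional assay for inhibition, with Homo sapiens as the target (a higher number here means a weaker inhibitor, a lower number a stronger inhibitor), a limit of the assay.
Compound 2 `CC(C)(C)c1nc(Br)c2cnnc(O)n12` gives 19000 nM in this assay.
Compound 3 `Oc1nncc2cncn12` gives > 48000 nM in this assay, again a limit.

Compound 3 thus sits at the limit, as does compound 1 (the limit of > 48000 nM in this assay, at which 2 of the 3 values shown sit). Among the measured compounds shown here, the only measured step, a step that the two limits leave unreadable from compound 1 to compound 3, is unreadable.

Compound 4 `CC(C)(C)c1ncc2cnnc(O)n12` differs from compound 3 by tert-butyl in place of hydrogen on an aromatic carbon. For the measured compounds named here, no measured step bears on this change directly. Compound 2 also carries the tert-butyl and gives a readable value, so compound 4 is expected to land near or somewhat inside the limit. The step of an at least 1.6-fold lower number from compound 3 to compound 4 (0.20 log units; that floor lies within the scatter) is estimated as small, toward stronger inhibition, with a fair chance that only a limit is again recorded. Compound 4 is estimated at 30000 nM, range 10000 nM to 100000 nM.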

Compound 4, half-maximal inhibitory concentration: > 48000 nM
Compound 4 was reported as a limit (the forecaster's own chance of this, stated with the estimate: 40%); at least 1.6-fold (0.20 log units) between middle value and limit.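

Tert-butyl in place of hydrogen on this aromatic carbon, between two ring nitrogen atoms, does not alone bring a readable value in this assay, and the step from the unsubstituted compound cannot be read, since both ends are limits. With tert-butyl kept, hydrogen in place of bromo gives an at least 2.5-fold higher number from compound 2 to compound 4 (0.40 log units; beyond the scatter), so the readable value of compound 2 requires the bromo in this pair. Compound 4 sits at a limit of the assay: the limit of > 48000 nM in this assay, at which 3 of the 4 values shown sit.

On these data alone, whether bromo gives a readable value without tert-butyl remains open. Also open, as far as these compounds go, is whether chloro or an amine in place of bromo would retain it.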